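The source may report more compounds than this note shows. Statements on the series, on what has been measured and on what is new or still open speak of the compounds shown alone.

In a functional assay on MCF7 cells (Homo sapiens) for cytotoxicity, read by fluorescence, with a stated time of 72 h (on this read-out lower numbers stand for stronger inhibition and higher numbers for weaker inhibition), three compounds sharing one core have been measured. Compound 1 (`CSc1nc(NCc2ccc(-c3ccccn3)cc2)c2[nH]nc(C(C)C)c2n1`) gives 819 nM, compound 2 (`CC(C)c1n[nH]c2c(NCc3ccc(-c4ccccn4)cc3)nc(S(C)(=O)=O)nc12`) gives 460 nM, and compound 3 (`CC(C)c1n[nH]c2c(NCc3ccc(-c4ccccn4)cc3)nc(N3CCCCC3CCO)nc12`) gives 133 nM, the lowest number of the three. Methylsulfonyl in place of methylsulfanyl gives a 1.8-fold lower number from compound 1 to compound 2 (0.25 log units; within the scatter). Placing 2-(2-hydroxyethyl)piperidin-1-yl on the same carbon gives a 6.2-fold lower number from compound 1 to compound 3 (0.79 log units; beyond the scatter) against methylsulfanyl and a 3.5-fold lower number from compound 2 to compound 3 (0.54 log units; beyond the scatter) against methylsulfonyl.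

Compound 4 (`CC(C)c1n[nH]c2c(NCc3ccc(-c4ccccn4)cc3)nc(NCCN)nc12`) has (2-aminoethyl)amino in place of 2-(2-hydroxyethyl)piperidin-1-yl on an aromatic carbon, the one between two ring nitrogen atoms: (2-aminoethyl)amino in place of 2-(2-hydroxyethyl)piperidin-1-yl on an aromatic carbon. Going by the values given here, no measured step brings in this group, so the data give no direct size for the change. Among the compounds with values here, the three steps at this carbon are the only guide, and they run from within the scatter to modest. Within the data shown here, compound 3, at 133 nM, holds the lowest number so far, so a replacement of its group seems more likely to raise the number than to lower it. A small move upward is therefore expected, with a 1.5-fold higher number from compound 3 to compound 4 (0.18 log units; within the scatter) as the estimated step. For compound 4 the estimated value is 200 nM, with an expected range from 60 nM to 650 nM.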

Compound 4, half-maximal inhibitory concentration: 62 nM
Compound 4: middle estimate off by 3.2-fold (0.51 log units), on the high side; measured number inside the range.
By their numbers in this assay, from the lowest: compound 4; then compound 3; then compounds 2 and 1 (each within the scatter of the next).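

At the aromatic carbon between two ring nitrogen atoms, this assay now shows that a six-membered non-aromatic ring is not required for the lowest number in the series: the open-chain (2-aminoethyl)amino group, with fewer heavy atoms than 2-(2-hydroxyethyl)piperidin-1-yl, gives a 2.1-fold lower number from compound 3 to compound 4 (0.33 log units; beyond the scatter) and so moves past the previous best group at this carbon. Against the two sulfur-bearing groups, the same amino group gives a 7.4-fold lower number from compound 2 to compound 4 (0.87 log units; beyond the scatter) from methylsulfonyl and a 13-fold lower number from compound 1 to compound 4 (1.12 log units; beyond the scatter) from methylsulfanyl, the latter being the largest step at this carbon among the compounds shown. Nothing available explains why these numbers fall with this change.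

The compounds shown leave open which feature of the new group matters, since a 2-hydroxyethylamino group, a 3-aminopropylamino chain, a dimethylamino group at the end of the ethyl chain or a piperazine ring would each separate a different part of it. They also leave open whether the ring or the hydroxyethyl arm of 2-(2-hydroxyethyl)piperidin-1-yl accounts for the gap between compound 3 and compound 4, as a plain piperidine or an open-chain 2-hydroxyethylamino group would test.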